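Extending a Side Chain on a Shared Core

This account rests on a few compounds, and the source may have more. Where it says the series, first, only, none or still open, it means among the compounds named here.

Of the compounds shown here, three built on one shared core have been tested in a functional assay on CFPAC-1 cells (Homo sapiens) for antiproliferative activity, read by MTT assay, with a stated time of 72 h; on this read-out lower numbers stand for stronger inhibition and higher numbers for weaker inhibition. Compound 1 `O=C1O[C@H]([C@@H](O)Cn2cc(-c3cc(C(F)(F)F)cc(C(F)(F)F)c3)nn2)C(OCc2ccccc2)=C1OCc1ccccc1` gives 66500 nM. Compound 3 `CCCCc1cn(C[C@H](O)[C@H]2OC(=O)C(OCc3ccccc3)=C2OCc2ccccc2)nn1` gives 73200 nM, the highest of the two numbers recorded, yet its gap to compound 1 lies within the scatter of repeated measurements, so the two cannot be ranked against each other. Compound 2 `CCCCCc1ccc(-c2cn(C/C=C3\OC(=O)C(OCc4ccccc4)=C3OCc3ccccc3)nn2)cc1` reached only (the limit of > 100000 nM in this assay, at which 1 of the 3 values shown sits); its result, > 100000 nM, is a limit of this assay and not a number.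

Compound 4 `CCCCCCCCCCc1cn(C[C@H](O)[C@H]2OC(=O)C(OCc3ccccc3)=C2OCc2ccccc2)nn1` has not yet been measured. It differs from compound 3 by hexyl in place of hydrogen on a saturated chain carbon, four bonds along the chain from an aromatic carbon. Going by the values given here, no measured pair here shows the effect of such a change, so the expectation rests on compound 3 alone. The expected step, a 1.5-fold lower number from compound 3 to compound 4 (0.17 log units; within the scatter), is modest, leaning toward a lower number but not clearly beyond the scatter. Compound 4 is therefore estimated at 50000 nM, with a range from 15000 nM to 150000 nM.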

Compound 4, half-maximal inhibitory concentration: 40300 nM
The estimate for compound 4 lay 1.2-fold (0.09 log units) above the measured number, within the range that was stated.
By their numbers in this assay, from the lowest: compounds 4, 1 and 3 (each within the scatter of the next). At a limit, above all of these: compound 2.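

Hexyl in place of hydrogen on a saturated chain carbon, four bonds along the chain from an aromatic carbon, gives in this assay a 1.8-fold lower number from compound 3 to compound 4 (0.26 log units; within the scatter) as the first step between measured compounds that differ in one place. A chain extended by hexyl at this position therefore leaves the number inside the scatter, and compound 3 and compound 4 cannot be ranked against each other. Nothing in the data shown bears on why this step has the size it has.

On these data alone, whether a longer chain, or an amine or a carboxylic acid in place of hexyl, would move the number beyond the scatter remains open. Also open, as far as these compounds go, is whether the same change would give a step of similar size in another compound built on the shared core.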